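The source may report more compounds than this note shows. Statements on the series, on what has been measured and on what is new or still open speak of the compounds shown alone.

Notes on the urea series. Compound 1 `Cc1cc(C)c(NC(=O)N(Cc2ccc(-c3nnc(C)o3)cc2)C2CCCCCC2)c(C)c1` and compound 2 `Cc1cc(C)c(NC(=O)N(Cc2ccc(-c3ccccn3)cc2)C2CCCCCC2)c(C)c1` share the same core and differ only at the group on the para position of the benzyl ring. In a functional assay on a cell-free system (plasma) with sterol O-acyltransferase, Soat (Rattus norvegicus) as the target (a higher number here means that more compound is needed for the effect, a lower number that less compound is needed), compound 1 gives only a limit, > 0.32 mg/kg. In this assay compound 2 likewise gives only a limit, > 1 mg/kg. The step that the two limits leave unreadable from compound 1 to compound 2 is therefore not readable in size; the two limits the limit of > 0.32 mg/kg in this assay, at which 1 of the 2 values shown sits, and the limit of > 1 mg/kg in this assay, at which 1 of the 2 values shown sits, set where compound 1 and compound 2 sit, nothing more. Compound 3 `Cc1cc(C)c(NC(=O)N(Cc2ccc(-c3cc[nH]n3)cc2)C2CCCCCC2)c(C)c1` is not yet measured; it carries the change (1H-pyrazol-3-yl in place of pyridin-2-yl on an aromatic carbon). For the measured compounds named here, no measured step bears on this change, and both measured values are limits. For compound 3 in this assay an outcome near the measured limits is expected, giving the estimated step that the limit leaves unreadable from compound 2 to compound 3. The expected value for compound 3 is 1.5 mg/kg, within 0.5 mg/kg to 5 mg/kg, with a fair chance that only a limit is reported again.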

Compound 3, dose for half-maximal effect: > 1 mg/kg
Compound 3 ended at the assay's limit; the forecaster's own chance of this, stated with the estimate: 65%; the middle value lies beyond the limit too.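

For the compounds shown here, compound 1, compound 2 and compound 3 all give only limits in this assay, and no step among them can be read in size. The compounds shown leave open what dose each actually needs and whether 1H-pyrazol-3-yl, pyridin-2-yl and 5-methyl-1,3,4-oxadiazol-2-yl differ at all.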